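Swapping the Aryl Group on a Shared Core

A few compounds are considered here, and "the series" means these few. Any claim that something is new, unique, unknown or untested is made for them only; others in the source may bear on it.

Compound 1 `CC(=O)N1N=C(c2ccc3ccccc3c2)OC1c1ccc(Cl)cc1` is the reference point here. Within the data shown here, in a functional assay on MCF7 cells (Homo sapiens) for antiproliferative activity, read by MTT assay, with a stated time of 48 h (on this read-out lower numbers stand for stronger inhibition and higher numbers for weaker inhibition), compound 1 gives 2.63 ug/mL, the lowest of the two numbers measured so far. Among the measured compounds shown here, its only measured neighbour is compound 2 `CC(=O)N1N=C(c2ccc3ccccc3c2)OC1c1ccccc1F`, which in this assay gives 3.44 ug/mL; the step of a 1.3-fold higher number from compound 1 to compound 2 (0.12 log units; within the scatter) lies within the scatter of repeated measurements. Compound 3 `CC(=O)N1N=C(c2ccc3ccccc3c2)OC1c1ccncc1` has not yet been measured. It differs from compound 1 in one place: pyridin-4-yl in place of 4-chlorophenyl on a saturated ring carbon. For the measured compounds named here, no measured step makes exactly this change, so the only guide is the step from compound 1 to compound 2, in which a different aromatic group took the same position on the saturated ring carbon and the step stayed within the scatter. On that basis the step of a 1.3-fold higher number from compound 1 to compound 3 (0.12 log units; within the scatter) is expected to be small, with no clear direction beyond the scatter. Compound 3 is therefore estimated at 3.5 ug/mL in this assay, within a range from 1.5 ug/mL to 8 ug/mL.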

Compound 3, half-maximal inhibitory concentration: 2.56 ug/mL
Estimate against measurement, compound 3: 1.4-fold (0.14 log units) above; low and high end bracket the measured number.
By their numbers in this assay, from the lowest: compounds 3, 1 and 2 (each within the scatter of the next).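

In this assay, replacing a halogen-bearing phenyl ring with pyridin-4-yl adds a hydrogen-bond acceptor and a ring hetero atom at this position, yet the measurements show a 1.0-fold lower number from compound 1 to compound 3 (0.01 log units; within the scatter) and a 1.3-fold lower number from compound 2 to compound 3 (0.13 log units; within the scatter). The saturated ring carbon has now carried three different six-membered aromatic rings, one of them containing nitrogen, and the three compounds cannot be told apart by this read-out. No available evidence explains why this change leaves the number within the scatter.

On these data alone, all three compounds keep a six-membered aromatic ring at this position, so the effect of a cyclohexyl ring, a longer alkyl chain or an amine remains open. It is also unknown whether a phenyl ring bearing a carboxylic acid would stay within the same narrow range.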